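The source may hold more compounds than are shown below. What is called first, only, known or untested is meant among the compounds shown, and "the series" means these compounds.

Working notes on the series. Among the measured compounds shown here, compound 1 `C=CC1=C(C(=O)NC2CCCCC2)C(c2ccc(OC)cc2)OC1` in a functional assay on HeLa cells (Homo sapiens) for cytotoxicity, read by MTT assay, with a stated time of 24 h (a lower number here means a stronger inhibitor, a higher number a weaker inhibitor), gives 24800 nM, the lowest of the two numbers in hand; compound 3 `C=CC1=C(C(=O)O)C(c2ccc(OC)cc2)OC1` sits nearest with 44300 nM, and the step of a 1.8-fold higher number from compound 1 to compound 3 (0.25 log units; within the scatter) is the only change at the carbonyl carbon measured so far. Compound 2 `C=CC1=C(C(=O)NC2CCCCC2)C(c2ccc(F)cc2)OC1` reaches only a limit of this assay, > 100000 nM. For the measured compounds named here, the corresponding step of an at least 4.0-fold higher number from compound 1 to compound 2 (0.60 log units; beyond the scatter) is the one change on the aromatic carbon measured so far; the evidence on it is the limit of > 100000 nM in this assay, at which 1 of the 3 values shown sits.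

Compound 4 `C=CC1=C(C(=O)NCc2ccccc2F)C(c2ccc(OC)cc2)OC1` is not yet measured. It differs from compound 1 by 2-fluorobenzyl in place of cyclohexyl on an amide-type nitrogen. Neither measured step touches the amide nitrogen: the step from compound 1 to compound 3 replaces the whole cyclohexylamino group with hydroxy and stays within the scatter, while the step from compound 1 to compound 2 alters the aromatic ring of the shared core, not the amide. On this footing no step beyond the scatter is expected from compound 1 to compound 4; the estimated step is a 1.2-fold higher number from compound 1 to compound 4 (0.08 log units; within the scatter). For compound 4 in this assay the expected value is 30000 nM, with a range from 10000 nM to 100000 nM.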

Compound 4, half-maximal inhibitory concentration: > 100000 nM
Compound 4 gave a limit, no number (the forecaster's own chance of this, stated with the estimate: 20%); middle value at least 3.3-fold (0.52 log units) from the limit.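

In this assay compound 4 gives > 100000 nM, which is a limit of the assay and not a number. Among the compounds shown here, this is the first change measured on the amide-type nitrogen, and the step of an at least 4.0-fold higher number from compound 1 to compound 4 (0.60 log units; beyond the scatter) shows that this place is not indifferent to its substituent, in contrast to the earlier change at the carbonyl carbon, the step of a 1.8-fold higher number from compound 1 to compound 3 (0.25 log units; within the scatter). Of the two groups on this nitrogen, only cyclohexyl has given a number, so the step from cyclohexyl to 2-fluorobenzyl is known only as a lower bound: the limit of > 100000 nM in this assay, at which 2 of the 4 values shown sit.

The compounds shown do not separate the fluorine from the benzyl group itself, a question that an unsubstituted benzyl group on the same nitrogen would address. Also open, on these data alone, is whether a smaller non-aromatic ring such as cyclopentyl, or an open chain such as n-butyl, on this nitrogen would give a number close to that of compound 1 or would also reach the limit.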